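Chloro for fluoro on the sulfonyl-bearing ring

The source may hold more compounds than are shown below. What is called first, only, known or untested is meant among the compounds shown, and "the series" means these compounds.

Measured compounds:
Compound 1 `CC(O)(CS(=O)(=O)c1ccc(Cl)cc1)c1nc(-c2ccc([N+](=O)[O-])c(C(F)(F)F)c2)no1`: 91000 nM in a functional assay on DU-145 cells (Homo sapiens) for cytotoxicity, read by MTT assay; on this read-out lower numbers stand for stronger inhibition and higher numbers for weaker inhibition.
Compound 2 `CC(O)(CS(=O)(=O)c1ccc(F)cc1)c1nc(-c2ccc([N+](=O)[O-])c(C(F)(F)F)c2)no1`: in this assay compound 2 reaches only the limit > 100000 nM.
Compound 3 `CC(O)(CS(=O)(=O)c1ccc(F)cc1)c1nc(-c2ccccc2)no1`: in this assay compound 3 also reaches only the limit > 100000 nM.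

Two of the three values rest at the limit (the limit of > 100000 nM in this assay, at which 2 of the 3 values shown sit). Between the two measured compounds that share a core, the change chloro in place of fluoro on an aromatic carbon gives an at least 1.0-fold lower number from compound 2 to compound 1 (0.04 log units; that floor lies within the scatter). Compound 4 `CC(O)(CS(=O)(=O)c1ccc(Cl)cc1)c1nc(-c2ccccc2)no1` carries the same change on the core of compound 3, (chloro in place of fluoro on an aromatic carbon). The difference between the two cores is not broken down here. For compound 4 the step of a number no higher from compound 3 to compound 4 (the limit leaves the size open) is expected to stay small, because the measured step of an at least 1.0-fold lower number from compound 2 to compound 1 (0.04 log units; that floor lies within the scatter) sits inside the scatter and compound 3 gives only a limit. Compound 4 is therefore estimated at 100000 nM, between 45000 nM and 300000 nM, with a fair chance that only a limit is reported.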

Compound 4, half-maximal inhibitory concentration: > 100000 nM
Compound 4 gave a limit, no number; the forecaster's own chance of this, stated with the estimate: 60%; the middle value sits exactly at the limit.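

In this assay, for the compounds shown here, compound 3 and compound 4 both give only a limit, so no step between them can be read: the limit of > 100000 nM in this assay, at which 3 of the 4 values shown sit. On these data alone, what chloro in place of fluoro does on the core of compound 3 stays open.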